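A few compounds are considered here, and "the series" means these few. Any claim that something is new, unique, unknown or untested is made for them only; others in the source may bear on it.

In a functional assay on MCF7 cells (Homo sapiens) for cytotoxicity, read by MTT assay, with a stated time of 24 h, tested at 16 ug/mL (on this read-out higher numbers stand for a stronger effect at the one concentration tested and lower numbers for a weaker effect), compound 1 `Cn1c(-c2ccc(NC(=O)CSc3nc4ccccc4s3)cc2)nc(-c2ccccc2)c1-c1ccccc1` gives 50.3%. Compound 2 `Cc1nnc(SCC(=O)Nc2ccc(-c3nc(-c4ccccc4)c(-c4ccccc4)n3C)cc2)s1` gives 74.9%, the step being a number 24.6 percentage points higher from compound 1 to compound 2 (beyond the scatter). Compound 3 `CN(C)/C=C/N1CCN(CC(=O)Nc2ccc(-c3nc(-c4ccccc4)c(-c4ccccc4)n3C)cc2)CC1` gives 19.4%, the lowest of the three numbers; the steps into it are a number 30.9 percentage points lower from compound 1 to compound 3 (beyond the scatter) and a number 55.5 percentage points lower from compound 2 to compound 3 (beyond the scatter), both beyond the scatter, so compound 3 sits clearly under compounds 1 and 2. Compound 4 `Cc1ccc(CN2CCN(CC(=O)Nc3ccc(-c4nc(-c5ccccc5)c(-c5ccccc5)n4C)cc3)CC2)cc1` has not yet been measured. The change from compound 3 to compound 4 is 4-methylbenzyl in place of 2-(dimethylamino)ethenyl on an amine nitrogen in a ring. Going by the values given here, none of the measured steps bears on this position: the two steps into compound 3 exchange the whole group on the saturated chain carbon bound to the carbonyl carbon, and no measured pair differs only in the group on the ring nitrogen. Among the compounds with values here, there is therefore no precedent for direction or size, and the expected step in this assay is a number 12.6 percentage points higher from compound 3 to compound 4 (beyond the scatter), not clearly beyond the scatter. For compound 4 the estimated value is 32%, with a range from 14% to 58%.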

Compound 4, a percentage reported as activity, at one concentration (the size of the read-out at that concentration, not a potency): 26%
The estimate for compound 4 lay 6 percentage points above the measured number, and the stated range covers the measured number.
By their numbers in this assay, from the lowest: compounds 3 and 4 (each within the scatter of the next); then compound 1; then compound 2.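

Going by these compounds alone, this is the first reading at the amine nitrogen in the ring: in this assay the exchange gives a number 6.6 percentage points higher from compound 3 to compound 4 (within the scatter), so these two groups are not told apart at this position. The entering 4-methylbenzyl brings one six-membered aromatic ring of carbon only and removes the double bond outside aromatic rings and the hydrogen-bond acceptor of 2-(dimethylamino)ethenyl, yet this one pair shows no separation beyond the scatter. No measured evidence bears on this outcome.

On these data alone, it remains open whether a much smaller substituent on that nitrogen, such as a methyl or acetyl group, or a longer chain ending in a carboxylic acid, would move the number beyond the scatter. Also open, as far as these compounds go, is whether the methyl on the benzyl group matters, which an unsubstituted benzyl or a 4-chlorobenzyl group on the same nitrogen would address.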